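The compounds below may be only part of what the source reports. "The series", "measured", "known", "first", "only" and "open" are said of these compounds alone.

Compound 1 `CSc1nc(-c2cccc(O)c2)c2c(N)c(C(=O)NC(C)(C)C)sc2n1` was examined in a functional assay on HEK293 cells for agonist activity at lutropin-choriogonadotropic hormone receptor (Homo sapiens), read by cAMP accumulation (on this read-out lower numbers stand for an effect already at smaller amounts and higher numbers for an effect only at larger amounts of compound), where compound 1 gives 1900 nM. That is the higher of the two numbers recorded so far. Compound 2 `COc1cccc(-c2nc(SC)nc3sc(C(=O)N(C)C(C)(C)C)c(N)c23)c1`, which carries a methoxy group rather than a hydroxy group, gives 800 nM in this assay, a number lower than that of compound 1 by a margin beyond the usual scatter. For compound 3 `COc1cccc(-c2nc(SC)nc3sc(C(=O)NN)c(N)c23)c1`, the entry in this assay reads "not determined" (no result reported), so no number is available for it.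

Compound 4 `COc1cccc(-c2nc(SC)nc3sc(C(=O)NC(C)(C)C)c(N)c23)c1F` differs from compound 1 in a single place: 2-fluoro-3-methoxyphenyl in place of 3-hydroxyphenyl on an aromatic carbon. Within the data shown here, no pair of measured compounds differing in just one place is available to calibrate this step, so the direction must be read from the compounds at hand. The expectation is a modest move toward lower numbers, a 2.7-fold lower number from compound 1 to compound 4 (0.43 log units; beyond the scatter), chiefly because compound 2 with its methoxy group gives 800 nM. Compound 4 is therefore estimated at 700 nM in this assay, with a likely range from 200 nM to 2500 nM.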

Compound 4, half-maximal effective concentration: 1500 nM
Estimate against measurement, compound 4: 2.1-fold (0.33 log units) below; the measured number falls inside the stated range.
By their numbers in this assay, from the lowest: compounds 2, 4 and 1 (each within the scatter of the next, the first and the last beyond it).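

In this assay, among these compounds, putting 2-fluoro-3-methoxyphenyl in place of 3-hydroxyphenyl on this aromatic carbon gives a 1.3-fold lower number from compound 1 to compound 4 (0.10 log units; within the scatter), the first step that changes one place only. The position therefore accepts the larger aryl group, which has a fluorine added and no hydrogen-bond donor, without any difference that can be told from the scatter, so that donor is not required for a number of this size in this pair. Nothing measured here explains why the two numbers stay so close.

The fluorine and the methyl on the oxygen entered together, so what each does alone cannot be read from this step, and either could be offsetting the other. From the compounds shown here alone, it also remains open how this position would respond to an amine or a carboxylic acid on the aryl ring, or to a longer chain such as ethoxy in place of methoxy.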